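From 2,5-dimethylphenyl to 4-ethylphenyl on a sulfonamide

The compounds below may be only part of what the source reports. "The series", "measured", "known", "first", "only" and "open" are said of these compounds alone.

Measured in a functional assay on Huh-7 cells (Homo sapiens) for inhibition, read by CCK-8 assay, with a stated time of 72 h; on this read-out lower numbers stand for stronger inhibition and higher numbers for weaker inhibition:
- compound 1 `Cc1cccc(NS(=O)(=O)c2cccc(CCCCCCNC(=O)/C=C/c3cccnc3)c2)c1`: 13.2 nM
- compound 2 `Cc1ccc(C)c(NS(=O)(=O)c2cccc(CCCCCCNC(=O)/C=C/c3cccnc3)c2)c1`: 2.58 nM

Compound 2 has the lower number of the two. Compound 3 `CCc1ccc(NS(=O)(=O)c2cccc(CCCCCCNC(=O)/C=C/c3cccnc3)c2)cc1` keeps the shared core and differs only on the sulfonamide nitrogen: 4-ethylphenyl in place of 2,5-dimethylphenyl on a sulfonamide nitrogen. For the measured compounds named here, the one measured step, a 5.1-fold lower number from compound 1 to compound 2 (0.71 log units; beyond the scatter), was modest and came from a methyl in place of hydrogen on an aromatic carbon. Compound 3 no longer has the 2,5-dimethylphenyl group, so a higher number of similar size is expected in this assay. The expected change is a 3.5-fold higher number from compound 2 to compound 3 (0.54 log units; beyond the scatter). For compound 3 the estimated value is 9 nM, with an expected range of 2.8 nM to 30 nM.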

Compound 3, half-maximal inhibitory concentration: 34.6 nM
Estimate against measurement, compound 3: 3.8-fold (0.58 log units) below; measured number outside the range, above it.
By their numbers in this assay, from the lowest: compound 2; then compound 1; then compound 3.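

Swapping 2,5-dimethylphenyl for 4-ethylphenyl leaves the same number of carbons on the sulfonamide nitrogen, yet in this assay it gives a 13-fold higher number from compound 2 to compound 3 (1.13 log units; beyond the scatter), so the arrangement of those carbons on the ring matters here, not only their count. Replacing 3-methylphenyl with 4-ethylphenyl gives a 2.6-fold higher number from compound 1 to compound 3 (0.42 log units; beyond the scatter), so the larger 4-ethylphenyl group also falls behind a ring with a single methyl. Nothing measured here explains these differences.

Still open, as far as these compounds go, is how a methoxy group or an amine on this ring would compare with the methyl and ethyl groups. From the compounds shown here alone, a chlorine or a propyl group in their place is equally open.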